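Direct aryl link on the thiazole: compound 2 to compound 4

The source may hold more compounds than are shown below. What is called first, only, known or untested is meant among the compounds shown, and "the series" means these compounds.

The series shares one core, first seen in compound 1 `CCCCCN1CCN(c2nc(N)nc3sc(-c4ccc(F)cc4)nc23)CC1`. In a functional assay on cells (Lymphocyte, Homo sapiens) (on this read-out higher numbers stand for weaker inhibition and lower numbers for stronger inhibition), compound 1 gives only a limit of the assay, > 10000 nM, which is the limit of > 10000 nM in this assay, at which 1 of the 3 values shown sits. For the measured compounds named here, compound 3 `Nc1nc(N2CCN(C(=O)COc3ccc(F)cc3)CC2)c2nc(-c3ccc(F)cc3)sc2n1` differs from compound 1 in one place, and the step of an at least 140-fold lower number from compound 1 to compound 3 (2.15 log units; beyond the scatter) is the only measured step in this set. Compound 2 `Nc1nc(N2CCN(C(=O)COc3ccc(Cl)cc3)CC2)c2nc(CCc3ccc(F)cc3)sc2n1` gives 4400 nM in this assay, the highest of the two numbers shown; compound 3 gives 70 nM, and no single step connects these two compounds.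

Compound 4 `Nc1nc(N2CCN(C(=O)COc3ccc(Cl)cc3)CC2)c2nc(-c3ccc(Cl)cc3)sc2n1` is not yet measured. It differs from compound 2 by 4-chlorophenyl in place of 2-(4-fluorophenyl)ethyl on an aromatic carbon. Going by the values given here, no measured step addresses this change; the one step measured concerns the amine nitrogen in a ring, not the aromatic carbon of the five-membered ring. Compound 3, which carries an aryl group directly on that carbon, gives 70 nM. Compound 4 is therefore expected to show a step of a 44-fold lower number from compound 2 to compound 4 (1.64 log units; beyond the scatter) toward stronger inhibition, and its estimated value in this assay is 100 nM, within 30 nM to 400 nM.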

Compound 4, half-maximal inhibitory concentration: 270 nM
Compound 4: the middle estimate sits 2.7-fold (0.43 log units) below what was measured; measured number inside the range.
By their numbers in this assay, from the lowest: compound 3; then compound 4; then compound 2. At a limit, above all of these: compound 1.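

For the compounds shown here, the step of a 16-fold lower number from compound 2 to compound 4 (1.21 log units; beyond the scatter) is the first measured change on the aromatic carbon of the five-membered ring; the only earlier step lay on the amine nitrogen in a ring. In this assay the read-out therefore moves strongly with the group at this carbon, with the rest of compound 2 held unchanged. The change alters two things at once, removing the ethyl chain and exchanging fluorine for chlorine on the phenyl ring, so this step cannot assign the shift to either, and nothing measured here explains it.

Still open, as far as these compounds go, is how a 2-(4-chlorophenyl)ethyl group or a 4-fluorophenyl group would read at this carbon, either of which would separate the chain from the halogen. Also open, from the compounds shown here alone, is how an amine or a carboxylic acid on the aryl ring, or a chain longer than ethyl, would read there.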